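The source may hold more compounds than are shown below. What is called first, only, known or untested is meant among the compounds shown, and "the series" means these compounds.

Working notes on the series.

Two compounds of this set have a number in an assay on isolated protein (Gallus gallus) for inhibition of transmembrane prolyl 4-hydroxylase (Homo sapiens); a higher number here means a weaker inhibitor, a lower number a stronger inhibitor. Compound 1 `COc1ccc(NC(=O)c2ccc(C(=O)O)nc2)cc1` gives 21100 nM in this assay. Compound 2 `O=C(Nc1ccc(C(=O)O)nc1)c1ccc(Cl)cc1` gives 22500 nM in this assay. The two numbers sit within the scatter of each other, so neither compound 1 nor compound 2 can be set apart on potency; compound 2 stands at the same level as compound 1, with nothing in the data to separate them.

Compound 3 `CN(C)c1ccc(C(=O)Nc2ccc(C(=O)O)nc2)cc1` is the next member and has no number yet in this assay. It differs from compound 2 in one place: dimethylamino in place of chloro on an aromatic carbon. Within the data shown here, no step between measured compounds touches this position, so the size of the step in this assay cannot be read from the data. Among the measured compounds shown here, the only comparison at hand is compound 1 against compound 2, where a different substituent at the same ring left the number within the scatter. The step from compound 2 to compound 3 is therefore expected to be a 1.1-fold lower number from compound 2 to compound 3 (0.05 log units; within the scatter), with no clear direction beyond the scatter. The estimate for compound 3 in this assay is 20000 nM, in the range from 8000 nM to 50000 nM.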

Compound 3, half-maximal inhibitory concentration: 11300 nM
Compound 3: middle estimate off by 1.8-fold (0.25 log units), on the high side, and the stated range covers the measured number.
By their numbers in this assay, from the lowest: compounds 3, 1 and 2 (each within the scatter of the next).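

Working notes, continued.

In this assay, among these compounds, the change at this position gives a 2.0-fold lower number from compound 2 to compound 3 (0.30 log units; within the scatter), the first step that can be read here, and it stays within the scatter even though it is larger than the gap between the two earlier numbers. On an aromatic carbon para to a large group, chloro can therefore give way to dimethylamino, a larger group with more heavy atoms and a hydrogen-bond acceptor, without a change in the number that can be told from the scatter, so this single pair gives no firm direction for the position. No measurement in hand explains the size or the direction of this step.

Still open, on these data alone, is whether any group at this position can move the number beyond the scatter: a primary amine, a carboxylic acid, a morpholine ring or a longer alkyl chain would each test the position further than this one pair can. Also open, as far as these compounds go, is whether the same exchange of chloro for dimethylamino would give a step of similar size on another core, since this step rests on one pair of compounds in one assay.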